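This account rests on a few compounds, and the source may have more. Where it says the series, first, only, none or still open, it means among the compounds named here.

Working notes on the series. Compound 1 `CCCCC#Cc1nc(NCC)c2ncn([C@H]3[C@H](O)[C@H](O)[C@@H]4C[C@@H]43)c2n1` gives 176 nM in an assay on RBL-2H3 cells for displacement of a labelled ligand from adenosine receptor A3 (Rattus norvegicus), with a stated time of 60 min; on this read-out higher numbers stand for weaker inhibition and lower numbers for stronger inhibition. Compound 2 `CCCCC#Cc1nc(NC)c2ncn([C@H]3[C@H](O)[C@H](O)[C@@H]4C[C@@H]43)c2n1` gives 231 nM in this assay. The only step measured so far, a 1.3-fold higher number from compound 1 to compound 2 (0.12 log units; within the scatter), removes a carbon from the chain on the exocyclic ring nitrogen and leaves the number essentially where it was: the values of compound 2 and compound 1 lie within the scatter of each other, so compound 2 cannot be set apart from compound 1 on the numbers shown.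

Compound 3 `CCCCC#Cc1nc(N)c2ncn([C@H]3[C@H](O)[C@H](O)[C@@H]4C[C@@H]43)c2n1` continues the same trimming one bond further in. The change is hydrogen in place of methyl on a nitrogen on an aromatic ring, read one bond further out as methylamino to amino. Going by the values given here, only the step from compound 1 to compound 2 bears on it, and that step was within the scatter. The structural change is of the same kind and the same size in heavy atoms, so the expectation is a small step, if any, most likely toward a slightly higher number, and not a step beyond the scatter. The estimated step is a 1.3-fold higher number from compound 2 to compound 3 (0.11 log units; within the scatter). Compound 3 is therefore expected to give about 300 nM in this assay, with a range from 120 nM to 800 nM.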

Compound 3, inhibition constant: 65 nM
Beside the measured number, compound 3's estimate is 4.6-fold (0.66 log units) above it; the measured number lies below the stated range.
By their numbers in this assay, from the lowest: compound 3; then compounds 1 and 2 (each within the scatter of the next).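

On the nitrogen on an aromatic ring, removal of the last carbon does what the earlier trimming did not: in this assay the change from methylamino to amino gives a 3.6-fold lower number from compound 2 to compound 3 (0.55 log units; beyond the scatter) and hydrogen in place of ethyl gives a 2.7-fold lower number from compound 1 to compound 3 (0.43 log units; beyond the scatter) while the step of a 1.3-fold higher number from compound 1 to compound 2 (0.12 log units; within the scatter) stayed within the scatter. The series therefore shows no steady trend with chain length at this position: compound 1 and compound 2 cannot be set apart, and only compound 3, with the free amino group, separates from both. No measurement at hand accounts for the separation appearing with the loss of the last carbon and not with the earlier one.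

From the compounds shown here alone, whether a longer chain such as propyl or a ring such as cyclopropyl on this nitrogen would stay within the scatter of compound 1 and compound 2 remains open. Also open, going by these compounds, is whether an acetyl group on the same nitrogen would give a number nearer to compound 3 or to the two alkylated compounds, and whether the same order holds on any other receptor.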